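This account rests on a few compounds, and the source may have more. Where it says the series, first, only, none or still open, it means among the compounds named here.

Series notes, M14 cytotoxicity.

Among the measured compounds shown here, in a functional assay on M14 cells (Homo sapiens) for inhibition, read by sulforhodamine B assay, with a stated time of 48 h (on this read-out lower numbers stand for higher toxicity in this test and higher numbers for lower toxicity in this test), compound 1 `Nc1cc(N)c2nc(-c3ccccc3)c(Sc3ccc(F)cc3)nc2c1` gives 58900 nM, the highest of the three numbers measured so far, with compound 3 `COc1ccc(CNc2nc3cc(N)cc(N)c3nc2-c2ccccc2)cc1` closest at 57500 nM and compound 2 `COc1ccc(CNc2nc3cc(N)cc(N)c3nc2-c2ccccc2)cc1OC` furthest at 33900 nM; both gaps lie within the scatter. For the measured compounds named here, the only single-point step measured so far is a 1.7-fold higher number from compound 2 to compound 3 (0.23 log units; within the scatter), so removing the methoxy from that benzylamine side chain left this assay unmoved.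

Compound 4 `COc1ccc(Sc2nc3cc(N)cc(N)c3nc2-c2ccccc2)cc1` differs from compound 1 by methoxy in place of fluoro on an aromatic carbon. Going by the values given here, no measured pair carries exactly this exchange on the sulfanyl aryl ring; the step from compound 2 to compound 3 is the only one touching a methoxy, and it stayed within the scatter. With the three numbers spanning less than the usual scatter, there is no ground to expect a change beyond it in this assay for compound 4, in either direction.

The expected step is therefore a 1.1-fold lower number from compound 1 to compound 4 (0.03 log units; within the scatter), and compound 4 is estimated at 55000 nM, within a range of 25000 nM to 120000 nM.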

Compound 4, concentration lethal to 50% of the cells: < 100000 nM
Compound 4 was reported as a limit; the forecaster's own chance of this, stated with the estimate: 10%; the middle value lies beyond the limit too.
By their numbers in this assay, from the lowest: compounds 2, 3 and 1 (each within the scatter of the next).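

In this assay, among the compounds shown here, compound 4 is reported only as a limit (< 100000 nM), so no step from compound 1 to compound 4 can be read. The compounds shown leave open whether methoxy in place of fluoro on an aromatic carbon changes this read-out in either direction.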